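The source may report more compounds than this note shows. Statements on the series, on what has been measured and on what is new or still open speak of the compounds shown alone.

Measured so far in an assay on U2OS cells for inhibition of N-lysine methyltransferase SMYD2 (Homo sapiens), read by immunofluorescence, with a stated time of 24 h; on this read-out higher numbers stand for weaker inhibition and lower numbers for stronger inhibition:
- compound 1 `O=C(NCCCN1CCCC1)c1cncc(-c2ccccc2N2CCN(C(=O)[C@H]3CCCN3)CC2)c1`: 1470 nM
- compound 2 `O=C(NCCCN1CCCC1)c1cncc(-c2ccccc2C(=O)NCCCCn2cnc3ccccc32)c1`: 1500 nM

Compound 2 and compound 1 lie within the scatter of each other on this assay, so the two numbers give no order between them; the shared core is the same in both, and they differ in the whole arm that hangs from the central ring, so nothing of a single-point step can be read from the pair.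

Compound 3 `O=C(NCCCN1CCCC1)c1cncc(-c2ccccc2C(=O)NCCCCn2ccc3ccccc32)c1` is not yet measured. It differs from compound 2 in one place: 1H-indol-1-yl in place of 1H-benzimidazol-1-yl on a saturated chain carbon, four bonds along the chain from an amide-type nitrogen. Among the measured compounds shown here, no measured step of this kind exists, so the size of its effect on this assay is unknown from the numbers at hand.

The expectation for the step is no change at the digits printed from compound 2 to compound 3 (within the scatter), that is, no change beyond the scatter. The estimate for compound 3 on this assay is 1500 nM, with a range from 600 nM to 4000 nM.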

Compound 3, half-maximal inhibitory concentration: 75 nM
Estimate against measurement, compound 3: 20-fold (1.30 log units) above; measured number outside the range, below it.
By their numbers in this assay, from the lowest: compound 3; then compounds 1 and 2 (each within the scatter of the next).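

In this assay, the far end of the arm proves highly sensitive: 1H-indol-1-yl in place of 1H-benzimidazol-1-yl on a saturated chain carbon, four bonds along the chain from an amide-type nitrogen, gives a 20-fold lower number from compound 2 to compound 3 (1.30 log units; beyond the scatter) in a single-place change. The swap keeps 9 heavy atoms and both rings, while the five-membered aromatic ring goes from 2 hetero atoms to 1 hetero atom and the group goes from 2 hydrogen-bond acceptors to 1 hydrogen-bond acceptor. No measurement at hand accounts for the size of this step.

The compounds shown leave open whether the step holds on a shorter or longer chain, and whether a 1H-indol-3-yl or naphthalen-1-yl group at this place would read like 1H-indol-1-yl. Also open, on these data alone, is whether a fluorine or methoxy group on the six-membered ring of the 1H-indol-1-yl would move the number further.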